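Oxadiazole series: a 4-methylbenzyl replacement at the five-membered ring

A few compounds are considered here, and "the series" means these few. Any claim that something is new, unique, unknown or untested is made for them only; others in the source may bear on it.

Measured compounds and their values in an assay for inhibition of Amine oxidase [flavin-containing] A (Homo sapiens), read by fluorescence and spectrophotometry, using microsomes, with stated times of 30 min and 20 min; on this read-out higher numbers stand for weaker inhibition and lower numbers for stronger inhibition:
Compound 1 `CC1CN=C(c2ccc(-c3noc(-c4ccc(Cl)c(Cl)c4)n3)cc2)N1` gives 14700 nM.
Compound 2 `Cc1nn(Cc2nc(-c3cccc(C4=NCCN4)c3)no2)c(=O)c2ccccc12` gives 62200 nM.
Compound 3 `CC(C)c1noc(-c2ccc(C3=NCCN3)cc2)n1` gives 22500 nM.

Of the three numbers, compound 3 stands second highest. Its nearest neighbour is compound 1, whose number is lower by an amount that lies within the usual scatter, so no order between compound 1 and compound 3 can be read from these two values. Compound 2 stands furthest off, with a number higher than that of compound 3 by a margin beyond the scatter.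

Compound 4 `Cc1ccc(Cc2noc(-c3ccc(C4=NCCN4)cc3)n2)cc1` is not yet measured. The change from compound 3 is 4-methylbenzyl in place of isopropyl on an aromatic carbon. For the measured compounds named here, no pair among the measured compounds differs in exactly this way, so the size of the step has no direct precedent. The expectation is a small step, if any, with a lowering of the number more likely than a rise, but not beyond the scatter: a 1.5-fold lower number from compound 3 to compound 4 (0.18 log units; within the scatter) is the expected step. For compound 4 the expected value in this assay is 15000 nM, with a range from 4000 nM to 55000 nM.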

Compound 4, half-maximal inhibitory concentration: 55500 nM
Estimate against measurement, compound 4: 3.7-fold (0.57 log units) below; measured number above the stated range.
By their numbers in this assay, from the lowest: compounds 1 and 3 (each within the scatter of the next); then compounds 4 and 2 (each within the scatter of the next).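

In this assay, for the compounds shown here, the only direct reading at this position, the aromatic carbon between two ring nitrogen atoms, is a 2.5-fold higher number from compound 3 to compound 4 (0.39 log units; beyond the scatter) for 4-methylbenzyl in place of isopropyl. The position therefore responds to this change: 8 heavy atoms with one six-membered aromatic ring, against 3 heavy atoms and no ring, go with weaker inhibition, while neither group carries a hydrogen-bond donor, a hydrogen-bond acceptor or a net charge. No measurement at hand gives a reason for this step.

A single step cannot show whether the ring, the methyl on it or the overall count of atoms goes with the change. Also open, as far as these compounds go, is how a plain benzyl, a shorter chain such as methyl, an amine or a carboxylic acid would read at this position.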